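Swapping benzyl for 4-nitrophenyl in compound 1

The source may report more compounds than this note shows. Statements on the series, on what has been measured and on what is new or still open speak of the compounds shown alone.

Compound 1 `CCCCCCCCCCCCCCCCCCNC(=O)[C@H]1CSC(Cc2ccccc2)N1` has been tested in a functional assay on PC-3 cells (Homo sapiens) for antiproliferative activity, read by sulforhodamine B assay (a lower number here means a stronger inhibitor, a higher number a weaker inhibitor), where compound 1 gives 16400 nM, the highest of the two numbers recorded. For the measured compounds named here, its one measured neighbour is compound 2 `CCCCCCCCCCCCCCCCCCNC(=O)[C@H]1CSC(c2ccc(N(C)C)cc2)N1`, which in this assay gives 6000 nM; the step of a 2.7-fold lower number from compound 1 to compound 2 (0.44 log units; beyond the scatter) exchanges benzyl for 4-(dimethylamino)phenyl on a saturated ring carbon. Compound 3 `CCCCCCCCCCCCCCCCCCNC(=O)[C@H]1CSC(c2ccc([N+](=O)[O-])cc2)N1` is not yet measured. It differs from compound 1 as follows: 4-nitrophenyl in place of benzyl on a saturated ring carbon. Going by the values given here, the only step that bears on this change is a 2.7-fold lower number from compound 1 to compound 2 (0.44 log units; beyond the scatter), which likewise replaces benzyl by a substituted phenyl at the same saturated ring carbon, though the substituent differs. One step is thin ground, so only a modest lowering is expected: the step from compound 1 is estimated as a 2.1-fold lower number from compound 1 to compound 3 (0.31 log units; beyond the scatter). Compound 3 is therefore expected to give about 8000 nM in this assay, within a range from 3000 nM to 25000 nM.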

Compound 3, half-maximal inhibitory concentration: about 20000 nM
Compound 3: the middle estimate sits 2.5-fold (0.40 log units) below what was measured, within the range that was stated.
By their numbers in this assay, from the lowest: compound 2; then compounds 1 and 3 (each within the scatter of the next).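

In this assay, putting a substituted phenyl on this saturated ring carbon in place of benzyl does not by itself change the reading: 4-nitrophenyl and benzyl cannot be told apart (a 1.2-fold higher number from compound 1 to compound 3 (0.09 log units; within the scatter)). The substituent on the aromatic ring does separate the compounds, since exchanging dimethylamino for nitro on an aromatic carbon gives a step beyond the scatter (a 3.3-fold higher number from compound 2 to compound 3 (0.52 log units; beyond the scatter)), so the lowering seen with compound 2 cannot be read as general to substituted phenyl groups, and compound 3 goes against such a reading. Nothing available accounts for the difference between these two substituents.

The compounds shown leave open where unsubstituted phenyl, a primary amine or a methoxy group in the same place would fall. They also leave open whether the gap between dimethylamino and nitro would persist with a shorter chain.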